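Chloro for trifluoromethyl in a series at its limit

This account rests on a few compounds, and the source may have more. Where it says the series, first, only, none or still open, it means among the compounds named here.

In a functional assay on HepG2 cells (Homo sapiens) for antiproliferative activity, read by MTT assay, with a stated time of 24 h (on this read-out lower numbers stand for stronger inhibition and higher numbers for weaker inhibition), compound 1 `COc1cccc(/C=C/C(=O)c2ccc(OC)c3c2OC(C)(C)C=C3)c1` gives > 10000 nM as a limit and not a number. Compound 2 `COc1ccc(C(=O)/C=C/c2ccc(C(F)(F)F)cc2)c2c1C=CC(C)(C)O2` gives > 10000 nM as a limit too, so it has no number of its own. Going by the values given here, compound 2 shares one reading with compound 1 (the limit of > 10000 nM in this assay, at which 2 of the 2 values shown sit), and the series offers no measured step. Compound 3 `COc1ccc(C(=O)/C=C/c2ccc(Cl)cc2)c2c1C=CC(C)(C)O2` carries chloro in place of trifluoromethyl on an aromatic carbon, para to a large group (chloro in place of trifluoromethyl on an aromatic carbon). No step beyond the scatter is expected in this assay and a further limit is likely. Compound 3 is estimated at 15000 nM with 5000 nM to 40000 nM as the expected range.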

Compound 3, half-maximal inhibitory concentration: > 10000 nM
Compound 3: no number, only a limit; the forecaster's own chance of this, stated with the estimate: 65%; the middle value lies beyond the limit too.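

No step can be read between compound 1, compound 2 and compound 3 in this assay, as each reading is a limit and not a number: the limit of > 10000 nM in this assay, at which 3 of the 3 values shown sit.

The compounds shown leave open whether chloro and trifluoromethyl differ at all in this read-out.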